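Chloro Added on the Fused Core: Growth Inhibition Notes

A few compounds are considered here, and "the series" means these few. Any claim that something is new, unique, unknown or untested is made for them only; others in the source may bear on it.

Of the compounds shown here, two have been tested in a functional assay on SF-539 cells (Homo sapiens) for cytotoxicity, read by sulforhodamine B assay, with a stated time of 48 h; on this read-out higher numbers stand for weaker inhibition of growth and lower numbers for stronger inhibition of growth. Compound 1 `ClCc1cccc(Cn2cnc3ncnc(Cl)c32)c1` gives 36300 nM in this assay. Compound 2 `ClCc1cccc(Cn2cnc3c(Cl)ncnc32)c1` gives 35500 nM in this assay. The two values sit within the scatter of each other, so compound 2 stands on the lower of the two numbers only by a margin that means nothing, and no order between the two can be read.

Compound 3 `ClCc1cccc(Cn2cnc3c(Cl)nc(Cl)nc32)c1` has not been measured. It differs from compound 2 by chloro in place of hydrogen on an aromatic carbon. No step between measured compounds isolates this change, so its size cannot be read from the numbers shown; the only guide is that the two measured compounds, which differ only in where the chloro group sits on the shared core, give the same number within scatter. A small step is expected, not beyond the scatter, in either direction. For compound 3 the expected value in this assay is 30000 nM, with a range from 12000 nM to 70000 nM. The estimated step is a 1.2-fold lower number from compound 2 to compound 3 (0.07 log units; within the scatter), expected to stay within the usual scatter.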

Compound 3, concentration for total growth inhibition: 14100 nM
Compound 3: middle estimate off by 2.1-fold (0.33 log units), on the high side; the range from low to high includes it.
By their numbers in this assay, from the lowest: compound 3; then compounds 2 and 1 (each within the scatter of the next).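

Chloro in place of hydrogen on the aromatic carbon between two ring nitrogen atoms gives a 2.5-fold lower number from compound 2 to compound 3 (0.40 log units; beyond the scatter) in this assay and is the first step in the series that lies beyond the scatter. This carbon of the six-membered aromatic ring is therefore a place where a single added chloro group moves the read-out measurably, although the step is modest, whereas compounds 1 and 2, with their chloro groups at different places on the shared core, could not be put in any order. The numbers show the size and direction of the step but nothing measured here bears on its cause.

As far as these compounds go, whether this step belongs to chloro in particular stays open, since one substituent at one carbon cannot separate it from other groups, and an amine, a methoxy group or a nitrile on the same carbon would show how specific the change is. Also open, from the compounds shown here alone, is whether the same addition would give a step of similar size on the core of compound 1, where the other chloro group stands at a different place.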